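Methyl on the Shared Core: Compound 1 to Compound 3

The source may hold more compounds than are shown below. What is called first, only, known or untested is meant among the compounds shown, and "the series" means these compounds.

Measured compounds:
compound 1 `O=c1[nH]cnc2c1c(-c1ccccc1)cn2-c1ccc(S(=O)(=O)Nc2ccccn2)cc1` gives 4670 nM
compound 2 `N#Cc1c(-c2ccccc2)cn(-c2ccc(S(=O)(=O)Nc3ccccn3)cc2)c1NC(=O)CCC(=O)O` gives 3750 nM

Compound 1 has the highest of the two numbers in a functional assay on HepG2 cells (Homo sapiens) for inhibition, read by sulforhodamine B assay, with a stated time of 24 h (a lower number here means a stronger inhibitor, a higher number a weaker inhibitor), yet its nearest neighbour, compound 2, lies within the scatter of it, so the two cannot be ranked against each other. Compound 3 `Cc1nc2c(c(-c3ccccc3)cn2-c2ccc(S(=O)(=O)Nc3ccccn3)cc2)c(=O)[nH]1` is not yet measured. It differs from compound 1 in one place: methyl in place of hydrogen on an aromatic carbon, an aromatic carbon between two ring nitrogen atoms of the fused two-ring core. Going by the values given here, no step between measured compounds resembles this change, so there is nothing in the data to anchor a direction. A single added carbon, carrying no donor or acceptor, is expected to leave the number roughly where compound 1 stands, with a step no larger than the scatter in either direction. For compound 3 the expected value in this assay is 4200 nM, with a range from 1500 nM to 12000 nM, which amounts to an expected step of a 1.1-fold lower number from compound 1 to compound 3 (0.05 log units; within the scatter).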

Compound 3, half-maximal inhibitory concentration: 3150 nM
Estimate against measurement, compound 3: 1.3-fold (0.12 log units) above, within the range that was stated.
By their numbers in this assay, from the lowest: compounds 3, 2 and 1 (each within the scatter of the next).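

In this assay, going by these compounds alone, the exchange of hydrogen for methyl on an aromatic carbon between two ring nitrogen atoms gives a 1.5-fold lower number from compound 1 to compound 3 (0.17 log units; within the scatter) and so provides the first one-place comparison on the shared core. Compound 3 and compound 1 cannot be told apart in this read-out, so this position accepts a methyl without a step beyond the scatter, something compound 1 and compound 2 alone could not show. Nothing available explains the result or bears on it.

On these data alone, whether an amine, a carboxylic acid or a longer chain such as propyl on this same aromatic carbon would move the number beyond the scatter remains open. A single small step also leaves open whether this position matters at all in this assay or simply has little bearing on the number.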